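A few compounds are considered here, and "the series" means these few. Any claim that something is new, unique, unknown or untested is made for them only; others in the source may bear on it.

Working notes on the series, read in an in vitro ADME assay on microsomes from liver (Homo sapiens) for metabolic stability, tested at 1 uM; a lower number here means that the compound disappears faster, a higher number that the compound lasts longer. Compound 1 `CS(=O)(=O)Nc1ccc2c(c1)S(=O)(=O)N=C(C1=C(O)[C@@H]3[C@H]4CC[C@H](C4)[C@@H]3N(Cc3ccccc3Cl)C1=O)N2` gives only a limit, > 1 h. Compound 2 `COc1cccc(CN2C(=O)C(C3=NS(=O)(=O)c4cc(NS(C)(=O)=O)ccc4N3)=C(O)[C@@H]3[C@H]4CC[C@H](C4)[C@@H]32)c1` also gives only a limit, > 1 h. Compound 3 `CS(=O)(=O)Nc1ccc2c(c1)S(=O)(=O)N=C(C1=C(O)[C@@H]3[C@H]4CC[C@H](C4)[C@@H]3N(Cc3ccc(F)c(F)c3F)C1=O)N2` likewise gives only a limit, > 1 h, so no number fixes its place. Among the compounds with values here, the series so far shows (the limit of > 1 h in this assay, at which 3 of the 3 values shown sit). Compound 4 `CC(C)CCN1C(=O)C(C2=NS(=O)(=O)c3cc(NS(C)(=O)=O)ccc3N2)=C(O)[C@@H]2[C@H]3CC[C@H](C3)[C@@H]21` carries isobutyl in place of 2,3,4-trifluorophenyl on a saturated chain carbon bound to an amide-type nitrogen in a ring. The measured steps at this place are a step that the two limits leave unreadable from compound 1 to compound 2, a step that the two limits leave unreadable from compound 1 to compound 3 and a step that the two limits leave unreadable from compound 2 to compound 3. None gives a size or direction to carry over, so no clear change is expected in this assay. The expected step is a step that the limit leaves unreadable from compound 3 to compound 4. The estimate for compound 4 is 1.5 h, with an expected range of 0.6 h to 4 h.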

Compound 4, half-life: 0.617 h
For compound 4 the middle estimate is 2.4-fold (0.39 log units) above the measured one, within the range that was stated.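

In this assay, this position now gives its first readable steps, with isobutyl replacing each aromatic group: an at least 1.6-fold lower number from compound 3 to compound 4 (0.20 log units; that floor lies within the scatter), an at least 1.6-fold lower number from compound 2 to compound 4 (0.20 log units; that floor lies within the scatter) and an at least 1.6-fold lower number from compound 1 to compound 4 (0.20 log units; that floor lies within the scatter). Each floor lies within the scatter, so no size can yet be given to the change, and the steps among compound 1, compound 2 and compound 3 cannot be read. Only the compounds with an aromatic ring at this place remain at the limit: the limit of > 1 h in this assay, at which 3 of the 4 values shown sit.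

From the compounds shown here alone, how far compound 1, compound 2 and compound 3 lie beyond that limit remains open. So does how an amine, a carboxylic acid or a longer chain would read at this place.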